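Cytotoxicity of lipoyl-triazole coumarin conjugates: a bromo analogue

The compounds below may be only part of what the source reports. "The series", "measured", "known", "first", "only" and "open" are said of these compounds alone.

Compound 1 `O=C(CCCCC1CCSS1)NCc1cn(CCCOc2ccc3cc(-c4ccccc4)c(=O)oc3c2)nn1`: 23.1%
Compound 2 `COc1ccc(-c2cc3ccc(OCCCn4cc(CNC(=O)CCCCC5CCSS5)nn4)cc3oc2=O)cc1`: 65.7%

In a functional assay on PC-12 cells (Rattus norvegicus) for cytotoxicity, read by MTT assay, with stated times of 3 h and 2 h, tested at 50 uM (a higher number here means a stronger effect of the compound at the concentration tested, a lower number a weaker effect), compound 2 gives the higher of the two numbers; compound 1 sits well below it, and the step of a number 42.6 percentage points higher from compound 1 to compound 2 (beyond the scatter) lies beyond the scatter. Compound 3 `O=C(CCCCC1CCSS1)NCc1cn(CCCOc2ccc3cc(-c4ccc(Br)cc4)c(=O)oc3c2)nn1` differs from compound 2 by bromo in place of methoxy on an aromatic carbon. Going by the values given here, no measured step swaps one substituent for another on that ring; the one step known concerns methoxy replacing hydrogen, so the bromo analogue is expected to land between the two measured values. Compound 3 is estimated to give 45% (range 20% to 72%), a step of a number 20.7 percentage points lower from compound 2 to compound 3 (beyond the scatter) expected downward.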

Compound 3, a percentage reported as activity, at one concentration (the size of the read-out at that concentration, not a potency): 74.7%
Compound 3: the middle estimate sits 29.7 percentage points below what was measured, and the stated range ends below it.
By their numbers in this assay, from the lowest: compound 1; then compounds 2 and 3 (each within the scatter of the next).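

In this assay, the 4-bromophenyl and 4-methoxyphenyl groups cannot be told apart (a number 9 percentage points higher from compound 2 to compound 3 (within the scatter)). Bromo in place of hydrogen also gives a large step (a number 51.6 percentage points higher from compound 1 to compound 3 (beyond the scatter)), so among these compounds the stronger effect is not tied to methoxy alone. Nothing at hand explains why these two groups give such a similar result. The compounds shown leave open how an amine, a carboxylic acid or a longer chain on this aromatic carbon would read. They also do not tell whether the effect depends on the place on the ring.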